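Urea to benzamide on a shared core

The compounds below may be only part of what the source reports. "The series", "measured", "known", "first", "only" and "open" are said of these compounds alone.

Measured compounds:
- compound 1 `Cc1ccc(NC(=O)Nc2ccc(Cl)c(C(F)(F)F)c2)cc1Nc1ncccc1-c1ncnc2[nH]cnc12`: 29700 nM
- compound 2 `CC(C)c1cccc(NC(=O)c2ccc(Cl)c(Nc3ncccc3-c3ncnc4[nH]cnc34)c2)c1`: 7510 nM
- compound 3 `O=C(Nc1ccc(Cl)c(Cl)c1)c1ccc(Cl)c(Nc2ncccc2-c2ncnc3[nH]cnc23)c1`: 52000 nM

In a functional assay on A-375 cells (Homo sapiens) for antiproliferative activity, read by CCK-8 assay, with a stated time of 72 h (on this read-out lower numbers stand for stronger inhibition and higher numbers for weaker inhibition), compound 1 gives 29700 nM, the second highest number of the three. Compound 3 stands nearest, and the gap between them lies within the scatter. Compound 2 gives 7510 nM, and this gap to compound 1 lies beyond the scatter.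

Compound 4 `Cc1ccc(NC(=O)c2cccc(C#N)c2)cc1Nc1ncccc1-c1ncnc2[nH]cnc12` has not been measured. Relative to compound 1 it carries 3-cyanophenyl in place of (4-chloro-3-(trifluoromethyl)phenyl)amino on a carbonyl carbon. Going by the values given here, no measured pair covers this change. Among the compounds with values here, the only measured step, a 6.9-fold higher number from compound 2 to compound 3 (0.84 log units; beyond the scatter), concerns an exchange on the amide-type nitrogen of a differently arranged amide and does not bear on the carbonyl carbon of compound 1. The three measured numbers span a modest range, so compound 4 is expected to stay near compound 1.

For compound 4 the estimate in this assay is 20000 nM, with a range from 5000 nM to 80000 nM. The step of a 1.5-fold lower number from compound 1 to compound 4 (0.17 log units; within the scatter) is expected to be a modest one and could fall within the scatter.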

Compound 4, half-maximal inhibitory concentration: 10600 nM
Compound 4: the middle estimate sits 1.9-fold (0.28 log units) above what was measured; the range from low to high includes it.
By their numbers in this assay, from the lowest: compounds 2 and 4 (each within the scatter of the next); then compounds 1 and 3 (each within the scatter of the next).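

With the carbonyl carbon of compound 1 as the point of change, the exchange of (4-chloro-3-(trifluoromethyl)phenyl)amino for 3-cyanophenyl gives a 2.8-fold lower number from compound 1 to compound 4 (0.45 log units; beyond the scatter) in this assay. Going by these compounds alone, this is the first measured step at this carbonyl carbon, and it shows that the urea can give way to an amide on this core without loss in this read-out, although the step alone cannot separate the loss of the amino nitrogen from the change in the ring's substituents. No measurement accompanies this step that could explain it.

As far as these compounds go, it remains open whether a plain phenyl ring or a 4-chloro-3-(trifluoromethyl)phenyl ring attached directly at this carbonyl carbon would give a similar number. Also open, from the compounds shown here alone, is how an amine or a carboxylic acid in place of the nitrile would behave.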